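Para-halogen step in the propargyl amide series

The compounds below may be only part of what the source reports. "The series", "measured", "known", "first", "only" and "open" are said of these compounds alone.

Measured so far in a functional assay on the whole organism (strain Icem-CET (SPF Caw)) for inhibition, with Mus musculus as the target, with a stated time of 30 min; a higher number here means that more compound is needed for the effect, a lower number that less compound is needed:
- compound 1, `C/C(C(=O)NC1CC1)=C(/C)c1ccc(Cl)cc1`, gives 11.4 mg/kg
- compound 2, `C#CCNC(=O)/C(C)=C(\C)c1ccc(F)cc1`, gives 22.8 mg/kg
- compound 3, `C#CCNC(=O)/C(C)=C(\C)c1ccccc1`, gives 45.3 mg/kg

Compound 3 stands at the highest of the three numbers in this assay. Its nearest neighbour is compound 2, and the gap a 2.0-fold higher number from compound 2 to compound 3 (0.30 log units; within the scatter) lies within the scatter, so the two cannot be ordered. Compound 1, which differs from compound 3 in two places, gives a lower number beyond the scatter.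

Compound 4, `C#CCNC(=O)/C(C)=C(\C)c1ccc(Cl)cc1`, is not yet measured. The change from compound 3 is chloro in place of hydrogen on an aromatic carbon. Going by the values given here, the one measured step that bears on it is the halogen step on the same aromatic carbon, a 2.0-fold higher number from compound 2 to compound 3 (0.30 log units; within the scatter), which was small. Among the compounds with values here, no measured pair isolates chloro against hydrogen on this core; compound 1 carries the chloro but also a different amide substituent, so its value is only a rough pointer.

For compound 4 in this assay a number of 18 mg/kg is expected, within 8 mg/kg to 40 mg/kg, a step of a 2.5-fold lower number from compound 3 to compound 4 (0.40 log units; beyond the scatter) that is expected to be modest and possibly within the scatter.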

Compound 4, dose for half-maximal effect: 10.6 mg/kg
For compound 4 the middle estimate is 1.7-fold (0.23 log units) above the measured one; measured number inside the range.
By their numbers in this assay, from the lowest: compounds 4, 1, 2 and 3 (each within the scatter of the next, the first and the last beyond it).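

In this assay, chloro in place of hydrogen on an aromatic carbon para to a large group gives a 4.3-fold lower number from compound 3 to compound 4 (0.63 log units; beyond the scatter) on the propargyl amide core, a step beyond the scatter, which the fluoro pair a 2.0-fold higher number from compound 2 to compound 3 (0.30 log units; within the scatter) did not show. Chloro and fluoro at this position can also be told apart, with a 2.2-fold lower number from compound 2 to compound 4 (0.33 log units; beyond the scatter) as the step, so the identity of the halogen counts here. With chloro in place, propargyl in place of cyclopropyl on the amide-type nitrogen gives a 1.1-fold lower number from compound 1 to compound 4 (0.03 log units; within the scatter) and the two compounds cannot be ordered, so compound 1 and compound 4 do not separate on the amide substituent. No measurement at hand offers a reason for these steps. As far as these compounds go, whether bromo, methoxy or trifluoromethyl at this position would follow chloro remains open. Also open, from the compounds shown here alone, is how an amine or a longer chain on the amide nitrogen would compare with propargyl and cyclopropyl.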